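A Carboxycyclopropyl Amide Awaits Its Number

A few compounds are considered here, and "the series" means these few. Any claim that something is new, unique, unknown or untested is made for them only; others in the source may bear on it.

Measured in a functional assay on MCF7 cells (Homo sapiens) for antiproliferative activity, read by MTT assay, with a stated time of 24 h (a lower number here means a stronger inhibitor, a higher number a weaker inhibitor), so far

compound 1 `CCn1c(C(=O)NC(C)(C)CO)ccc1C(CC)(CC)c1ccc(OCS(=O)(=O)c2ccccc2)c(C)c1` gives 20700 nM
compound 2 `CCn1c(C(=O)N[C@H](CO)CCCO)ccc1C(CC)(CC)c1ccc(OCS(=O)(=O)c2ccccc2)c(C)c1` gives 31400 nM

These two values lie within the scatter of each other, so compound 2 stands level with compound 1. Compound 3 `CCn1c(C(=O)NC2(C(=O)O)CC2)ccc1C(CC)(CC)c1ccc(OCS(=O)(=O)c2ccccc2)c(C)c1` carries 1-carboxycyclopropyl on the amide-type nitrogen, (a group of 6 heavy atoms (4 carbon, 2 oxygen; one three-membered non-aromatic ring of carbon only) in place of a group of 7 heavy atoms (5 carbon, 2 oxygen; no ring), on an amide-type nitrogen). For the measured compounds named here, the one measured step bearing on this is a 1.5-fold higher number from compound 1 to compound 2 (0.18 log units; within the scatter), made at the same nitrogen. Going by the values given here, no measured compound has a ring in this group, so that step is only a weak guide, and no change beyond the scatter is expected in this assay. The expected step is a 1.3-fold lower number from compound 2 to compound 3 (0.10 log units; within the scatter). The estimate for compound 3 is 25000 nM, with an expected range from 10000 nM to 60000 nM.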

Compound 3, half-maximal inhibitory concentration: 41200 nM
For compound 3 the middle estimate is 1.6-fold (0.22 log units) below the measured one, within the range that was stated.
By their numbers in this assay, from the lowest: compounds 1, 2 and 3 (each within the scatter of the next).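

With 1-carboxycyclopropyl on the amide-type nitrogen, a ring appears at this position for the first time among the compounds shown, and in this assay compound 3 stands level with compound 1 and compound 2 (a 1.3-fold higher number from compound 2 to compound 3 (0.12 log units; within the scatter); a 2.0-fold higher number from compound 1 to compound 3 (0.30 log units; within the scatter)). All three groups at this nitrogen, with or without a ring, thus give values within the scatter of one another. No evidence is at hand that bears on this result. From the compounds shown here alone, whether an amine or a cyclohexyl group on this nitrogen would give a number beyond the scatter stays open.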